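The source may report more compounds than this note shows. Statements on the series, on what has been measured and on what is new or still open speak of the compounds shown alone.

Measured compounds:
Compound 1, `COc1ccc2[nH]c(C(=O)N3CC(=O)N(Cc4ccccc4)[C@@H](CN4CC5CCCCC5C4)C3)cc2c1`: in an ADME assay on Vero cells (Chlorocebus sabaeus) for cytotoxicity, with a stated time of 7 days (a lower number here means that less compound is tolerated, a higher number that more compound is tolerated), compound 1 gives 8200 nM.
Compound 2, `COc1ccc2[nH]c(C(=O)N3CC(=O)N(Cc4ccccc4)[C@@H](CN4CCn5cccc5C4)C3)cc2c1`: in this assay compound 2 gives only a limit of the assay, > 100000 nM.

Compound 2 thus stands at the upper edge of what this assay reports, as noted in the limit of > 100000 nM in this assay, at which 1 of the 2 values shown sits, and the step of an at least 12-fold higher number from compound 1 to compound 2 (1.08 log units; beyond the scatter) is the only measured one. Compound 3, `COc1ccc2[nH]c(C(=O)N3CC(=O)N(Cc4ccccc4)[C@@H](CN4CCc5ccccc5C4)C3)cc2c1`, differs from compound 2 by a group of 10 heavy atoms (9 carbon, 1 nitrogen; one six-membered non-aromatic ring with 1 hetero atom, one six-membered aromatic ring of carbon only) in place of a group of 9 heavy atoms (7 carbon, 2 nitrogen; one five-membered aromatic ring with 1 hetero atom, one six-membered non-aromatic ring with 2 hetero atoms), on a saturated chain carbon bound to a saturated ring carbon. Among the measured compounds shown here, this change touches the same position as the measured step, but no measured pair shows this particular exchange, so the direction is not fixed by the data; the one step available runs from a group of carbon with one nitrogen to one holding two nitrogens, and compound 3 returns to a single nitrogen in the entering group. The step of an at least 2.8-fold lower number from compound 2 to compound 3 (0.45 log units; beyond the scatter) is therefore expected to be a moderate decrease, with a real chance that only a limit is reported again. Compound 3 is estimated at 35000 nM, within 9000 nM to 100000 nM.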

Compound 3, half-maximal cytotoxic concentration: 51800 nM
Beside the measured number, compound 3's estimate is 1.5-fold (0.17 log units) below it, within the range that was stated.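

In this assay, replacing the group of compound 1 with 1,2,3,4-tetrahydroisoquinolin-2-yl gives a 6.3-fold higher number from compound 1 to compound 3 (0.80 log units; beyond the scatter), so this position now has a higher number that is an actual reading and not a limit. Compound 2 and compound 3 both carry an aromatic ring in the group on the saturated chain carbon and both stand higher than compound 1, while the comparison between them gives only an at least 1.9-fold lower number from compound 2 to compound 3 (0.28 log units; that floor lies within the scatter). The true size of that last step stays unknown because compound 2 gives only a limit of the assay: the limit of > 100000 nM in this assay, at which 1 of the 3 values shown sits.

The compounds shown leave open whether the aromatic ring itself goes with the higher number, since compound 2 and compound 3 also differ in ring size and nitrogen count. They also leave open how an open-chain diethylamino group or a morpholine ring would read in this place.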